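A few compounds are considered here, and "the series" means these few. Any claim that something is new, unique, unknown or untested is made for them only; others in the source may bear on it.

Working notes on the series. In a functional assay on OVCAR-5 cells (Homo sapiens) for inhibition, with a stated time of 48 h, tested at 50 uM (a higher number here means more inhibition of growth at the concentration tested, a lower number less inhibition of growth), compound 1 (`C=C[C@@](C)(/C=C/c1ccc(OC(C)=O)cc1)CCC=C(C)C`) gives 71% and compound 2 (`C=C[C@@](C)(/C=C/c1ccc(OC(=O)CCCCCCC)cc1)CCC=C(C)C`) gives 42%. Going by the values given here, compound 2 therefore holds the lower of the only two numbers so far, and its gap to compound 1 is beyond the scatter.

Compound 3 (`C=C[C@@](C)(/C=C/c1ccc(OC)cc1)CCC=C(C)C`) has not yet been measured. Its change from compound 2 is methyl in place of heptylcarbonyl on an oxygen on an aromatic ring.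

Among the compounds with values here, one measured step bears on this: a number 29 percentage points lower from compound 1 to compound 2 (beyond the scatter). This modest step, beyond the scatter, places hexyl in place of hydrogen on a saturated chain carbon bound to a carbonyl carbon. Compound 3 removes that chain along with the carbonyl, so the step reads across only loosely. Within the data shown here, no measured compound carries methyl on that oxygen.

A rise in this assay of somewhat smaller size than the measured step is expected, and it should lie beyond the scatter. The estimated step is a number 20 percentage points higher from compound 2 to compound 3 (beyond the scatter). For compound 3 the expected value is 62%, with an estimated range of 44% to 80%.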

Compound 3, percent growth inhibition at one concentration: 37%
The estimate for compound 3 lay 25 percentage points above the measured number, and the stated range ends above it.
By their numbers in this assay, from the lowest: compounds 3 and 2 (each within the scatter of the next); then compound 1.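

In this assay, methyl in place of heptylcarbonyl on an oxygen on an aromatic ring gives a number 5 percentage points lower from compound 2 to compound 3 (within the scatter) and so leaves no readable difference between the ether and the long ester. Methyl in place of acetyl on the same oxygen gives a number 34 percentage points lower from compound 1 to compound 3 (beyond the scatter), and with the earlier step this sets compound 1 apart from both compound 2 and compound 3, so this position does respond to the group it carries, yet a carbonyl there is not enough on its own, as compound 2 has one and compound 3 has none. Nothing available accounts for the separate standing of the acetyl group.

The three compounds leave open whether acetyl is a lone case or the top of a narrow range of short esters, which propionyl and butyryl groups on this oxygen would address. From the compounds shown here alone, a free hydroxyl on the same oxygen, and a carbamate or a sulfonate in place of the ester, also remain open, so it cannot yet be said which feature of the acetyl group matters.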